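Phenyl for methyl on an oxygen across two cores

A few compounds are considered here, and "the series" means these few. Any claim that something is new, unique, unknown or untested is made for them only; others in the source may bear on it.

Compound 1 `CCOC(=O)c1c(-c2cccc(OC)c2)[nH]c2cc(Cl)c(OC)cc2c1=O` gives in an ADME assay on Raji cells (Homo sapiens) for cytotoxicity, read by luminescence, with a stated time of 72 h (a higher number here means that more compound is needed for the effect, a lower number that less compound is needed), only a limit, > 21500 nM.
Compound 2 `CCOC(=O)c1c(-c2cccc(Oc3ccccc3)c2)[nH]c2cc(Cl)c(OC)cc2c1=O` gives in this assay only a limit, > 21500 nM.
Compound 3 `CCOC(=O)c1c(-c2cccc(OC)c2)[nH]c2cc(Cl)c(Cl)cc2c1=O` gives in this assay only a limit, > 21500 nM.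

Compound 2 differs from compound 1 by phenyl in place of methyl on an oxygen on an aromatic ring. The step that this change made is a step that the two limits leave unreadable from compound 1 to compound 2, and it stays unreadable because of the limit of > 21500 nM in this assay, at which 3 of the 3 values shown sit. Compound 3 differs from compound 1 by chloro in place of methoxy on an aromatic carbon, and the step that the two limits leave unreadable from compound 1 to compound 3 is likewise hidden, since every value here is a limit rather than a number.

Compound 4 `CCOC(=O)c1c(-c2cccc(Oc3ccccc3)c2)[nH]c2cc(Cl)c(Cl)cc2c1=O` is not yet measured. Among the measured compounds shown here, it differs from compound 3 by phenyl in place of methyl on an oxygen on an aromatic ring, which is the same change as the one from compound 1 to compound 2, made at a place described in the same words; the two cores differ by chloro in place of methoxy on an aromatic carbon as already given.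

Since the three measured compounds all sit at the same limit, the step from compound 3 to compound 4 is expected to be a step that the limit leaves unreadable from compound 3 to compound 4, resting only on the fact that compound 1 and compound 2 both returned limits in this assay. Compound 4 is therefore estimated at 30000 nM in this assay, most likely reported again as a limit, with a range from 12000 nM to 90000 nM.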

Compound 4, half-maximal effective concentration: > 21500 nM
Compound 4: no number, only a limit (the forecaster's own chance of this, stated with the estimate: 85%); the middle value does not contradict the limit.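

In this assay compound 4 gives > 21500 nM, which is a limit and not a number. No new step can be read for compound 4 from compound 2 or compound 3, because all four compounds share one limit: the limit of > 21500 nM in this assay, at which 4 of the 4 values shown sit.

The compounds shown leave open whether phenyl in place of methyl, or chloro in place of methoxy, changes the cytotoxic concentration in this assay at all.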